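Amide to sulfonamide: expected cytotoxicity of compound 3

The compounds below may be only part of what the source reports. "The series", "measured", "known", "first", "only" and "open" are said of these compounds alone.

Compound 1 `O=C(Nc1ncc(Cc2ccc(Br)cc2)s1)c1ccc2ccccc2c1` was examined in an ADME assay on HepG2 2.2.15 cells (Homo sapiens) for cytotoxicity (on this read-out lower numbers stand for higher toxicity in this test and higher numbers for lower toxicity in this test), and gives only a limit, > 50000 nM, not a number. That limit is the one recorded as the limit of > 50000 nM in this assay, at which 1 of the 2 values shown sits. Compound 2 `CC(C)(C)C(=O)Nc1ncc(C(Oc2ccc3cc(Br)ccc3c2)c2ccc(Cl)cc2)s1` has no single number in this assay; it is simply reported as "not toxic" (no number reported), so it cannot be placed on either side of compound 1. Compound 3 `Cc1ccc(C)c(S(=O)(=O)Nc2ncc(C(Oc3ccc4cc(Br)ccc4c3)c3ccc(Cl)cc3)s2)c1` differs from compound 2 by (2,5-dimethylphenyl)sulfonyl in place of (tert-butyl)carbonyl on a nitrogen on an aromatic ring. Within the data shown here, with no measured step in this assay to lean on, the change from compound 2 to compound 3 is expected to stay within the scatter. Compound 3 is therefore estimated at 40000 nM, between 10000 nM and 100000 nM.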

Compound 3, half-maximal cytotoxic concentration: > 50000 nM
Compound 3 ended at the assay's limit (the forecaster's own chance of this, stated with the estimate: 60%); middle value at least 1.2-fold (0.09 log units) from the limit.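

No step can be read from compound 2 to compound 3, as compound 2 carries only the words "not toxic" and compound 3 gives only a limit: the limit of > 50000 nM in this assay, at which 2 of the 3 values shown sit.

The compounds shown leave open whether (2,5-dimethylphenyl)sulfonyl in place of (tert-butyl)carbonyl shifts the result in this assay at all.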